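Fluorophenyl for propargyloxyphenyl on the second core

The source may report more compounds than this note shows. Statements on the series, on what has been measured and on what is new or still open speak of the compounds shown alone.

Compound 1 `C#CCOc1cccc(/C=C/C(=O)Nc2cc(C(=O)c3cc(OC)c(OC)c(OC)c3)ccc2OC)c1` gives 12200 nM in a functional assay on B16 cells (Mus musculus) for cytotoxicity, read by MTT assay, with a stated time of 72 h; on this read-out higher numbers stand for weaker inhibition and lower numbers for stronger inhibition. Compound 2 `COc1ccc(C(=O)c2cc(OC)c(OC)c(OC)c2)cc1NC(=O)/C=C/c1ccc(F)cc1` differs from compound 1 by 4-fluorophenyl in place of 3-(propargyloxy)phenyl on a double-bonded chain carbon bound to a double-bonded chain carbon; in this assay compound 2 gives 400 nM, and the step is a 31-fold lower number from compound 1 to compound 2 (1.48 log units; beyond the scatter). Compound 3 `C#CCOc1cccc(/C=C/C(=O)Nc2cc(C(=O)c3cc(OC)c(OC)c(OC)c3)cc(OC)c2OC)c1` carries the other core of the series, differing from compound 1 by methoxy in place of hydrogen on an aromatic carbon; compound 3 gives 5100 nM in this assay, and the step is a 2.4-fold lower number from compound 1 to compound 3 (0.38 log units; beyond the scatter). Compound 4 `COc1cc(C(=O)c2cc(OC)c(OC)c(OC)c2)cc(NC(=O)/C=C/c2ccc(F)cc2)c1OC` has not been measured; it differs from compound 3 by 4-fluorophenyl in place of 3-(propargyloxy)phenyl on a double-bonded chain carbon bound to a double-bonded chain carbon. The place of this change reads word for word the same as in the pair from compound 1 to compound 2, so it is the same change, now made on the core of compound 3. Among the measured compounds shown here, only one measured instance exists, so the expectation rests on a single step. Set beside a 31-fold lower number from compound 1 to compound 2 (1.48 log units; beyond the scatter), the expected step in this assay is a 30-fold lower number from compound 3 to compound 4 (1.48 log units; beyond the scatter), because compound 3 starts from 5100 nM. Compound 4 is therefore estimated at 170 nM in this assay, with a likely range from 60 nM to 600 nM.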

Compound 4, half-maximal inhibitory concentration: 900 nM
Compound 4: middle estimate off by 5.3-fold (0.72 log units), on the low side; measured number above the stated range.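

In this assay the change to 4-fluorophenyl from 3-(propargyloxy)phenyl still lowers the number on the second core, a 5.7-fold lower number from compound 3 to compound 4 (0.75 log units; beyond the scatter), but the size of the step does not carry over: the same change on two cores in this assay, a 31-fold lower number (1.48 log units; beyond the scatter) from compound 1 to compound 2 and a 5.7-fold lower number (0.75 log units; beyond the scatter) from compound 3 to compound 4, 5.4-fold (0.73 log units) apart, beyond the scatter of two such steps

The added methoxy behaves differently on the two side chains, with a 2.3-fold higher number from compound 2 to compound 4 (0.35 log units; beyond the scatter), so its direction depends on which aryl group the compound carries: the same change on two cores in this assay, a 2.4-fold lower number (0.38 log units; beyond the scatter) from compound 1 to compound 3 and a 2.3-fold higher number (0.35 log units; beyond the scatter) from compound 2 to compound 4, 5.4-fold (0.73 log units) apart, beyond the scatter of two such steps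

The four compounds therefore show that the direction of the fluorophenyl change held on both cores while its size did not, and that the two changes do not add up independently; they do not show why, and a single pair per core gives no rule for the wider series.

Going by these compounds, whether the gap between the cores is special to 4-fluorophenyl stays open, as an amine or a carboxylic acid on the same phenyl ring could behave differently. On these data alone, it is also open whether the same dependence on the core appears in cells other than these.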